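The source may report more compounds than this note shows. Statements on the series, on what has been measured and on what is new or still open speak of the compounds shown alone.

Measured compounds in a physicochemical assay for solubility, read by nephelometry, measured as kinetic solubility, at pH 2; a lower number here means a less soluble compound, a higher number a more soluble compound:
Compound 1, `COc1ccc(-c2cc(-c3ccc(S(=O)(=O)N(C)C)cc3)cnc2N)cn1`: > 100 ug/mL.
Compound 2, `CNS(=O)(=O)c1ccc(-c2cnc(N)c(-c3ccc(OC)nc3)c2)cc1`: > 100 ug/mL.
Compound 3, `COc1ccc(-c2cc(-c3ccc(C(F)(F)F)cc3)cnc2N)cn1`: > 100 ug/mL.

Each of these three readings is a limit of the assay, not a number. Compound 3 thus stands at the limit in this assay, and the other two compounds stand at the same limit; this is the limit of > 100 ug/mL in this assay, at which 3 of the 3 values shown sit. The step from compound 1 to compound 3 is a step that the two limits leave unreadable from compound 1 to compound 3, the step from compound 2 to compound 3 is a step that the two limits leave unreadable from compound 2 to compound 3, and the step from compound 1 to compound 2 is a step that the two limits leave unreadable from compound 1 to compound 2. None of the three gives a readable size.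

Compound 4, `COc1ccc(-c2cc(-c3ccc(-n4cncn4)cc3)cnc2N)cn1`, is not yet measured. It differs from compound 3 in one place: 1H-1,2,4-triazol-1-yl in place of trifluoromethyl on an aromatic carbon. Within the data shown here, none of the measured steps involves a triazolyl group, so none bears directly on this change; they show only that dimethylsulfamoyl, methylsulfamoyl and trifluoromethyl on this aromatic carbon all leave the reading at the limit. The step in this assay from compound 3 to compound 4 is therefore expected to be unreadable again, with compound 4 most likely at the limit. The expected step is a step that the limit leaves unreadable from compound 3 to compound 4. For compound 4 the estimate in this assay is 120 ug/mL, with a range of 50 ug/mL to 250 ug/mL.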

Compound 4, solubility: > 100 ug/mL
Compound 4 was reported as a limit; the forecaster's own chance of this, stated with the estimate: 70%; the middle value is on the limit's open side.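

In this assay compound 4 gives > 100 ug/mL as a limit of the assay and not a number. The steps to compound 4 from compound 1, compound 2 and compound 3 cannot be read, because all the readings stand at one limit: the limit of > 100 ug/mL in this assay, at which 4 of the 4 values shown sit. The compounds shown leave open how far apart these four lie in solubility, and which group on this aromatic carbon, if any, gives a reading short of the limit.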